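Shifting the fluorine from compound 3 to compound 4

The compounds below may be only part of what the source reports. "The series", "measured", "known", "first", "only" and "open" are said of these compounds alone.

Compound 1 `Oc1ccc(-c2cc(-c3ccc(F)cc3)cc(-c3ccccc3O)n2)cc1`: > 50000 nM
Compound 2 `Oc1ccc(-c2cc(-c3ccc(F)cc3)cc(-c3cccc(O)c3)n2)cc1`: 8080 nM
Compound 3 `Oc1ccc(-c2cc(-c3cccc(F)c3)cc(-c3ccc(O)cc3)n2)cc1`: > 50000 nM

In a functional assay on HeLa cells (Homo sapiens) for inhibition (on this read-out lower numbers stand for stronger inhibition and higher numbers for weaker inhibition), compound 3 reaches only a limit, > 50000 nM. Compound 1 likewise gives only a limit, > 50000 nM. Both sit at the limit of > 50000 nM in this assay, at which 2 of the 3 values shown sit. Compound 2 gives 8080 nM, and the step of an at least 6.1-fold lower number from compound 1 to compound 2 (0.79 log units; beyond the scatter) concerns the hydroxyphenyl position alone. The change to compound 4 `Oc1ccc(-c2cc(-c3ccc(F)cc3)cc(-c3ccc(O)cc3)n2)cc1` is different: 4-fluorophenyl in place of 3-fluorophenyl on an aromatic carbon. Within the data shown here, no measured step bears directly on it; compound 2 does carry the entering 4-fluorophenyl alongside a 3-hydroxyphenyl and yields a number. Compound 4 is therefore expected to show an at least 2.0-fold lower number from compound 3 to compound 4 (0.30 log units; that floor lies within the scatter), with a real chance of another limit. The estimate for compound 4 is 25000 nM, ranging from 6000 nM to 80000 nM.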

Compound 4, half-maximal inhibitory concentration: 8680 nM
Beside the measured number, compound 4's estimate is 2.9-fold (0.46 log units) above it; the measured number falls inside the stated range.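

In this assay, 4-fluorophenyl in place of 3-fluorophenyl gives an at least 5.7-fold lower number from compound 3 to compound 4 (0.76 log units; beyond the scatter), so the fluorine's position on this ring matters when a 4-hydroxyphenyl group is present. With 4-fluorophenyl in place, 4-hydroxyphenyl and 3-hydroxyphenyl cannot be told apart, a 1.1-fold higher number from compound 2 to compound 4 (0.03 log units; within the scatter), whereas the change from 2-hydroxyphenyl gives an at least 5.7-fold lower number from compound 1 to compound 4 (0.76 log units; beyond the scatter). Compound 1 and compound 3 each stand at a limit, so those two steps give only floors: the limit of > 50000 nM in this assay, at which 2 of the 4 values shown sit.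

Going by these compounds, how far those two steps truly reach stays open. So does whether an amine or a carboxylic acid in place of the fluorine would hold this level.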